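This account rests on a few compounds, and the source may have more. Where it says the series, first, only, none or still open, it means among the compounds named here.

Measured so far in a functional assay on HT-29 cells (Homo sapiens) for cytotoxicity, read by MTT assay, with a stated time of 72 h; a lower number here means a stronger inhibitor, a higher number a weaker inhibitor:
compound 1 `COc1ccc(OC)c(/C=N/NC(=O)Nc2ccc(Oc3ccnc(-c4nncn4CCN(C)C)c3)c(F)c2)c1` gives 2070 nM
compound 2 `CN(C)CCn1cnnc1-c1cc(Oc2ccc(NC(=O)N/N=C/c3cccc(O)c3)cc2F)ccn1` gives 330 nM
compound 3 `COc1ccc(/C=N/NC(=O)Nc2ccc(Oc3ccnc(-c4nncn4CCN(C)C)c3)c(F)c2)cc1O` gives 960 nM

Compound 1 stands at the highest of the three numbers in this assay, and both of its steps to the other compounds run downward: a 2.2-fold lower number from compound 1 to compound 3 (0.33 log units; beyond the scatter), and a 6.3-fold lower number from compound 1 to compound 2 (0.80 log units; beyond the scatter). The remaining pair is also a single change: a 2.9-fold higher number from compound 2 to compound 3 (0.46 log units; beyond the scatter).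

Compound 4 `CN(C)CCn1cnnc1-c1cc(Oc2ccc(NC(=O)N/N=C/c3ccc(F)cc3F)cc2F)ccn1` is not yet measured. It differs from compound 1 in one place: 2,4-difluorophenyl in place of 2,5-dimethoxyphenyl on a carbon with a double bond to nitrogen. The two steps that bear on this are the two other replacements of the same 2,5-dimethoxyphenyl group, one modest and one somewhat larger, and both lowered the number in this assay. Each of those entering groups carried a hydroxyl, which 2,4-difluorophenyl does not, so the evidence points only loosely in one direction. A modest lowering is expected, a 1.7-fold lower number from compound 1 to compound 4 (0.24 log units; within the scatter), with a real chance that the step stays within the scatter. Compound 4 is therefore estimated at 1200 nM, in the range 400 nM to 3500 nM.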

Compound 4, half-maximal inhibitory concentration: 960 nM
Compound 4: the middle estimate sits 1.3-fold (0.10 log units) above what was measured; measured number inside the range.
By their numbers in this assay, from the lowest: compound 2; then compounds 3 and 4 (each within the scatter of the next); then compound 1.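

In this assay, the 2,4-difluorophenyl group carries no hydrogen-bond donors, yet replacing 2,5-dimethoxyphenyl with it still gives a 2.2-fold lower number from compound 1 to compound 4 (0.33 log units; beyond the scatter), so among these compounds a hydroxyl on the entering group is not needed for a lower number than that of compound 1. Against the hydroxyl-bearing groups the outcome is split: there is no change at the digits printed from compound 3 to compound 4 (within the scatter), but also a 2.9-fold higher number from compound 2 to compound 4 (0.46 log units; beyond the scatter), which leaves the 3-hydroxyphenyl group of compound 2 with the lowest number of the four. Nothing available explains these differences.

The compounds shown leave open whether the lower number of compound 4 comes from losing the two methoxy groups or from gaining the two fluorines. They also leave open how an unsubstituted phenyl or an aminophenyl would behave on this carbon.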